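Trading 1-hydroxyethyl for 1,3-thiazol-4-yl on the shared core

A few compounds are considered here, and "the series" means these few. Any claim that something is new, unique, unknown or untested is made for them only; others in the source may bear on it.

In an ADME assay on the whole organism (plasma, strain 129/SvEvBrd x C57BL/6) for pharmacokinetics, with Mus musculus as the target, at a dose of 10 mg/kg by the oral route (a higher number here means more compound in the circulation at the dose given, a lower number less compound in the circulation), compound 1 `CCc1[nH]c(C(C)=O)nc1[C@@H](O)[C@H](O)[C@H](O)CO` reaches 1650 ng.h/mL while compound 2 `CC(=O)c1nc([C@@H](O)[C@H](O)[C@H](O)CO)c(-c2ccccc2)[nH]1` reaches 3520 ng.h/mL and compound 3 `CC(O)c1nc([C@@H](O)[C@H](O)[C@H](O)CO)c[nH]1` reaches 10300 ng.h/mL as the highest of the three, clearly beyond the usual scatter from both others.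

The next compound to be measured is compound 4 `OC[C@@H](O)[C@@H](O)[C@H](O)c1c[nH]c(-c2cscn2)n1` which keeps the shared core of compound 3 but carries 1,3-thiazol-4-yl in place of 1-hydroxyethyl on an aromatic carbon. Among the measured compounds shown here, only one measured step offers a comparison (a 2.1-fold higher number from compound 1 to compound 2 (0.33 log units; beyond the scatter)) and there phenyl replaces ethyl on an aromatic carbon. That modest rise also puts a ring in place of a group without one, but it swaps different groups and so guides only loosely.

The values pull the other way. Neither compound 1 nor compound 2 carries 1-hydroxyethyl, and compound 2 (3520 ng.h/mL) is the closer of the two to compound 3 (10300 ng.h/mL) yet still clearly lower. Three compounds make a thin basis, but a moderate drop is expected. The estimated step is a 2.9-fold lower number from compound 3 to compound 4 (0.47 log units; beyond the scatter) in this assay as an expectation only. For compound 4 the estimate is 3500 ng.h/mL with an expected range from 800 ng.h/mL to 12000 ng.h/mL as its limits.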

Compound 4, area under the concentration-time curve: 1570 ng.h/mL
For compound 4 the middle estimate is 2.2-fold (0.35 log units) above the measured one; the measured number falls inside the stated range.
By their numbers in this assay, from the lowest: compounds 4 and 1 (each within the scatter of the next); then compound 2; then compound 3.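

Swapping 1-hydroxyethyl for 1,3-thiazol-4-yl on the aromatic carbon between two ring nitrogen atoms gives a 6.6-fold lower number from compound 3 to compound 4 (0.82 log units; beyond the scatter) in this assay and shows that the group at this position can matter greatly for the amount of compound in the circulation. The earlier step put a ring in place of ethyl and the number rose, whereas here a ring enters and the number falls, so compounds 2 and 4 go in opposite directions and the mere arrival of a ring sets no direction among the compounds shown. Several features change together in this swap, since a hydrogen-bond donor leaves and a larger group with a five-membered aromatic ring enters, and nothing available here separates their contributions or explains the fall.

Still open, on these data alone, is whether a small chain such as methyl, an amine, or a phenyl ring with no hetero atoms at this position would stay near compound 3 or fall towards compound 4. A single exposure figure after an oral dose also leaves open whether less compound enters the circulation or more of it leaves.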